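Swapping Bromo for Benzyloxy on a Shared Core

The compounds below may be only part of what the source reports. "The series", "measured", "known", "first", "only" and "open" are said of these compounds alone.

Three compounds have been measured in a functional assay on MDA-MB-231 cells (Homo sapiens) for cytotoxicity, read by MTT assay, with a stated time of 24 h; on this read-out lower numbers stand for stronger inhibition and higher numbers for weaker inhibition:

Compound 1, `Cc1cc(O)c(C(=O)/C=C/c2ccc(F)cc2)c(-c2ccc(OCc3ccccc3)cc2)c1C(=O)/C=C/c1ccc(F)cc1`: 15000 nM
Compound 2, `Cc1cc(O)c(C(=O)/C=C/c2ccc(OCc3ccccc3)cc2)c(-c2ccc(Br)cc2)c1C(=O)/C=C/c1ccc(OCc2ccccc2)cc1`: 20000 nM
Compound 3, `Cc1cc(O)c(C(=O)/C=C/c2ccc(F)cc2)c(-c2ccc(Br)cc2)c1C(=O)/C=C/c1ccc(F)cc1`: 22300 nM

Compound 3 and compound 1 differ in one place only: benzyloxy in place of bromo on an aromatic carbon. This single change gave a 1.5-fold lower number from compound 3 to compound 1 (0.17 log units; within the scatter), so the two numbers cannot be told apart with confidence. Compound 2 and compound 3 differ more widely; the difference between their two cores is not broken down here. In this assay compound 2 gives 20000 nM, and compound 3 gives 22300 nM, two numbers that lie within the scatter of each other. All three measured numbers sit close together at the weak end of the read-out.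

Compound 4, `Cc1cc(O)c(C(=O)/C=C/c2ccc(OCc3ccccc3)cc2)c(-c2ccc(OCc3ccccc3)cc2)c1C(=O)/C=C/c1ccc(OCc2ccccc2)cc1`, has not yet been measured. It arises from compound 2 by the same change that turns compound 3 into compound 1: benzyloxy in place of bromo on an aromatic carbon. The place of the change is described in the same words in both cases, so this is the same change made a second time on a different core. Within the data shown here, the expected step is a 1.5-fold lower number from compound 2 to compound 4 (0.17 log units; within the scatter), resting on the one measured example of this change, a 1.5-fold lower number from compound 3 to compound 1 (0.17 log units; within the scatter), which itself lies within the scatter. Among the measured compounds shown here, with only one example, the expectation is loose. In this assay compound 4 is estimated at 13500 nM, with a likely range from 5000 nM to 35000 nM.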

Compound 4, half-maximal inhibitory concentration: 20000 nM
The estimate for compound 4 lay 1.5-fold (0.17 log units) below the measured number, and the stated range covers the measured number.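

In this assay, putting benzyloxy in place of bromo on the core of compound 2 gave no change at the digits printed from compound 2 to compound 4 (within the scatter). Set beside the earlier case, the two cores show no difference that these numbers can detect: the same change on two cores in this assay, a 1.5-fold lower number (0.17 log units; within the scatter) from compound 3 to compound 1 and no change at the digits printed (within the scatter) from compound 2 to compound 4, 1.5-fold (0.17 log units) apart, within the scatter of two such steps. So the change carries over from one core to the other in a limited sense: on neither core does swapping a single bromine atom for the much larger benzyloxy group, with its extra aromatic ring, move the number beyond the scatter, but two cores are a small sample, and two steps this small cannot show that the change truly helps, truly does nothing, or would behave the same way on a further core.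

The compounds shown carry only bromo or benzyloxy at this place and only fluoro or benzyloxy at the ends of the two side chains, so it remains open whether an amine or a carboxylic acid at either site would shift the number beyond the scatter. On these data alone, it also remains open whether the same swap would matter on a core whose number lies away from the weak end of this read-out.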